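The source may report more compounds than this note shows. Statements on the series, on what has been measured and on what is new or still open speak of the compounds shown alone.

Measured so far:
- Compound 1 `C[C@@H](NC(=O)[C@H](CCCCN)NC(=O)[C@H](CCCc1ccccc1)[C@@](C)(O)C(=O)NO)c1ccccc1` — 149 nM
- Compound 2 `CNC(=O)[C@H](CCCNC(=O)OC(C)(C)C)NC(=O)[C@H](CCCc1ccccc1)[C@@](C)(O)C(=O)NO` — 2 nM

The two compounds were tested in an assay on isolated protein for binding affinity to matrix metalloproteinase-9 (Homo sapiens); on this read-out higher numbers stand for weaker inhibition and lower numbers for stronger inhibition. Compound 1 gives 149 nM in this assay, while compound 2 gives 2 nM. Compound 2 therefore stands at the lower of the two numbers, and the gap between compound 2 and compound 1 lies beyond the scatter, so compound 2 is the stronger inhibitor of the two. The two compounds differ in more than one place, so the gap between them cannot be tied to a single change.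

Compound 3 `CNC(=O)[C@@H](NC(=O)[C@H](CCCc1ccccc1)[C@@](C)(O)C(=O)NO)C(C)(C)C` has not yet been measured. It differs from compound 2 in one place: tert-butyl in place of 3-((tert-butoxycarbonyl)amino)propyl on a saturated chain carbon bound to an amide-type nitrogen and a carbonyl carbon. For the measured compounds named here, no step between two measured compounds matches this change, so there is no direct precedent to lean on. The shared core with its hydroxamate is kept. For compound 3 in this assay a step of about a 1.5-fold higher number from compound 2 to compound 3 (0.18 log units; within the scatter) is expected, that is, no change beyond the scatter. Compound 3 is thus estimated at 3 nM in this assay, with a range from 0.5 nM to 20 nM.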

Compound 3, inhibition constant: < 1 nM
Compound 3 ended at the assay's limit; the forecaster's own chance of this, stated with the estimate: 3%; middle value at least 3.0-fold (0.47 log units) away from the limit.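

In this assay compound 3 gives < 1 nM, which is a limit of the assay and not a number. Tert-butyl in place of 3-((tert-butoxycarbonyl)amino)propyl on a saturated chain carbon bound to an amide-type nitrogen and a carbonyl carbon gives an at least 2.0-fold lower number from compound 2 to compound 3 (0.30 log units; that floor lies within the scatter), so in this pair strong inhibition does not require the longer chain, and it persists with a group that has no hydrogen-bond donors or acceptors. How far the step reaches past that floor cannot be read: the limit of < 1 nM in this assay, at which 1 of the 3 values shown sits.

The compounds shown leave open how a carboxylic acid or a hydroxyl group on a chain at this position, or a smaller branched group such as isopropyl, would stand against tert-butyl in this assay. As far as these compounds go, compound 1 differs from compound 3 in more than one place and cannot settle what a free amine at the end of the chain does on its own, so the role of that group at this position also stays open.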